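Two fluorinated benzyl indoles in a cell tolerance assay

The source may report more compounds than this note shows. Statements on the series, on what has been measured and on what is new or still open speak of the compounds shown alone.

Compound 1, with the structure `CCOC(=O)/C(O)=C/C(=O)c1cn(Cc2cc(F)c(F)c(F)c2)c2cccc(OC)c12`, was examined in an ADME assay on MT4 cells (Homo sapiens) for cytotoxicity, read by MTT assay (a lower number here means that less compound is tolerated, a higher number that more compound is tolerated), where compound 1 gives 33400 nM. Its nearest companion is compound 2, `COc1cccc2c1c(C(=O)/C=C(\O)C(=O)O)cn2Cc1ccc(F)c(F)c1F`, which carries the same core and the same 3,4,5-trifluorobenzyl group but an acid in place of the ethyl ester; in this assay compound 2 gives 22800 nM. The two numbers sit within the usual scatter of one another, so neither compound can be said to be tolerated better or worse than the other on this evidence.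

Compound 3, `CCOC(=O)/C(O)=C/C(=O)c1cn(Cc2ccc(F)cc2F)c2cccc(OC)c12`, has not yet been measured. It differs from compound 1 only in the benzyl group: 2,4-difluorophenyl in place of 3,4,5-trifluorophenyl on a saturated chain carbon bound to an aromatic nitrogen. For the measured compounds named here, no step between measured compounds touches this part of the molecule, so there is nothing in the measured pairs to show which way the change will pull. Given that the only measured variation, between compound 1 and compound 2, stays inside the scatter, the step from compound 1 to compound 3 is expected to be a 1.1-fold lower number from compound 1 to compound 3 (0.05 log units; within the scatter), no more than the scatter itself. For compound 3 in this assay, the estimate is therefore 30000 nM, in a range from 12000 nM to 75000 nM.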

Compound 3, half-maximal cytotoxic concentration: 65500 nM
Compound 3: middle estimate off by 2.2-fold (0.34 log units), on the low side; the range from low to high includes it.
By their numbers in this assay, from the lowest: compounds 2, 1 and 3 (each within the scatter of the next, the first and the last beyond it).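

For the compounds shown here, the step at this position is the first one measured in this set: in this assay, 2,4-difluorophenyl in place of 3,4,5-trifluorophenyl on a saturated chain carbon bound to an aromatic nitrogen gives a 2.0-fold higher number from compound 1 to compound 3 (0.29 log units; within the scatter). Going by these compounds alone, the earlier compounds offered no single-place comparison, so this pair is the first direct reading of the group, and it shows that this exchange, from three fluorines on the ring to two in a different arrangement, stays inside the scatter, which gives no ground for ranking compound 1 and compound 3 against each other. No supporting measurement is available that would bear on this result or explain it.

This single exchange alters both the number of fluorines and their arrangement, so the pair cannot separate one from the other. The compounds shown also leave open how this assay would read with an unsubstituted phenyl, a chlorophenyl or a methoxyphenyl at the same place, or with a longer chain in place of the single carbon that carries the ring.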